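A few compounds are considered here, and "the series" means these few. Any claim that something is new, unique, unknown or untested is made for them only; others in the source may bear on it.

Of the compounds shown here, two have been measured in a functional assay on SW620/5-FU cells (Homo sapiens) for cytotoxicity, read by MTT assay, with a stated time of 48 h, in the presence of a further agent that is not named here; a higher number here means that more compound is needed for the effect, a lower number that less compound is needed. Compound 1, `CCN(CC)c1cc(NC(=O)NNc2cc(-c3ccc(F)cc3)c3cnn(C)c3n2)cc(Cl)n1`, gives 37000 nM in this assay, which is the higher of the two numbers. Compound 2, `CCCc1cc(NNC(=O)Nc2cc(Cl)nc(Cl)c2)nc2c1c(C(F)(F)F)nn2C`, gives 11700 nM in this assay, and the gap between the two numbers is beyond the usual scatter. These two compounds differ in several places at once, so their two values alone cannot be traced to any single change.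

Compound 3, `CCCCOc1cc(NC(=O)NNc2cc(-c3ccc(F)cc3)c3cnn(C)c3n2)cc(Cl)n1`, has not yet been measured. It differs from compound 1 in one place: butoxy in place of diethylamino on an aromatic carbon. Within the data shown here, no pair of measured compounds that differ only in this way is available, so there is no measured step on which to rest a direction.

With nothing to go on beyond the two measured compounds, the step of a 1.2-fold lower number from compound 1 to compound 3 (0.09 log units; within the scatter) is expected to stay within the scatter. Compound 3 is therefore estimated at 30000 nM in this assay, with a range from 10000 nM to 90000 nM.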

Compound 3, half-maximal effective concentration: 29300 nM
Compound 3: middle estimate off by 1.0-fold (0.01 log units), on the high side; the measured number falls inside the stated range.
By their numbers in this assay, from the lowest: compound 2; then compounds 3 and 1 (each within the scatter of the next).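

In this assay, among these compounds, the first pair of compounds that differ only at this aromatic carbon gives a 1.3-fold lower number from compound 1 to compound 3 (0.10 log units; within the scatter), so the two cannot be told apart in this read-out. At this position, then, diethylamino and butoxy, which match in their counts of heavy atoms, hydrogen-bond donors and hydrogen-bond acceptors, read alike on the shared core, at least for this one pair. No measurement at hand explains why these two groups read alike.

On these data alone, whether a shorter chain such as methoxy, a ring amine such as morpholine or a carboxylic acid at this carbon would read the same remains open. Also open, as far as these compounds go, is whether diethylamino and butoxy would still read alike if other parts of the shared core were changed.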